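Swapping a Saturated Ring for an Aromatic Amine

The source may report more compounds than this note shows. Statements on the series, on what has been measured and on what is new or still open speak of the compounds shown alone.

Compound 1 `NC(N)=NC(=O)c1nc(Cl)c(NC2CCCCC2)nc1N`: 92%
Compound 2 `NC(N)=NC(=O)c1nc(Cl)c(N2CCCCC2)nc1N`: 85%

Within the data shown here, in an assay for inhibition of acid-sensing ion channel 3 (Homo sapiens), read by patch clamp, tested at 20 uM (a higher number here means more inhibition at the concentration tested (going by the name of the read-out), a lower number less inhibition), compound 2 stands lowest of the two numbers, though the one measured step, a number 7 percentage points lower from compound 1 to compound 2 (within the scatter), lies within the scatter, so the two values cannot be ordered. Compound 3 `NC(N)=NC(=O)c1nc(Cl)c(Nc2ccccn2)nc1N` differs from compound 2 by (pyridin-2-yl)amino in place of piperidin-1-yl on an aromatic carbon. Among the measured compounds shown here, only a number 7 percentage points lower from compound 1 to compound 2 (within the scatter) bears on this change, and it was small; no measured compound carries an aromatic amine at this place, so the ground is thin. The step to compound 3 is expected to be a number 5 percentage points lower from compound 2 to compound 3 (within the scatter), none beyond the scatter. Compound 3 is estimated at 80%, ranging from 55% to 95%.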

Compound 3, a percentage reported as inhibition, at one concentration (the size of the read-out at that concentration, not a potency): 25%
For compound 3 the middle estimate is 55 percentage points above the measured one; the whole stated range lies above it.
By their numbers in this assay, from the lowest: compound 3; then compounds 2 and 1 (each within the scatter of the next).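

In this assay, what sits at this position on the shared core clearly matters: the change gives a number 60 percentage points lower from compound 2 to compound 3 (beyond the scatter) and the swap on the nitrogen gives a number 67 percentage points lower from compound 1 to compound 3 (beyond the scatter) while the two saturated rings, cyclohexylamino and piperidin-1-yl, stayed within the scatter of each other. An aromatic pyridin-2-yl on the nitrogen therefore goes with a large loss of inhibition that the earlier pair gave no sign of. Nothing measured here accounts for this loss. As far as these compounds go, whether a phenyl on the same nitrogen, which carries no ring nitrogen, would lose inhibition as well remains open.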